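A few compounds are considered here, and "the series" means these few. Any claim that something is new, unique, unknown or untested is made for them only; others in the source may bear on it.

Compound 2 `COc1cc(-c2cc(/C=C/C(=O)c3ccc(N)cc3)[nH]n2)cc(OC)c1OC` gives 5590 nM in a functional assay on NCI-H322M cells (Homo sapiens) for inhibition, read by sulforhodamine B assay, with a stated time of 48 h; on this read-out higher numbers stand for weaker inhibition of growth and lower numbers for stronger inhibition of growth. Compound 1 `COc1ccc(-c2cc(/C=C/C(=O)c3ccc(N)cc3)[nH]n2)cc1` gives 9270 nM in this assay; the two numbers in hand lie within the scatter of each other, so compound 2 is not separated from compound 1. Compound 3 `COc1cc(-c2cc(/C=C/C(=O)c3ccc(Cl)c(Cl)c3)[nH]n2)cc(OC)c1OC` is not yet measured in this assay. It differs from compound 2 by 3,4-dichlorophenyl in place of 4-aminophenyl on a carbonyl carbon. For the measured compounds named here, no measured pair shows this exchange, so the expected step is a 1.6-fold lower number from compound 2 to compound 3 (0.20 log units; within the scatter), with no measured ground to fix a direction beyond the scatter. Compound 3 is expected to give about 3500 nM in this assay, within a range from 900 nM to 14000 nM.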

Compound 3, concentration for total growth inhibition: > 100000 nM
Compound 3 ended at the assay's limit (the forecaster's own chance of this, stated with the estimate: 5%); middle value at least 28-fold (1.45 log units) away from the limit.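

On a carbonyl carbon, the aryl group matters in this assay: 3,4-dichlorophenyl in place of 4-aminophenyl gives an at least 17-fold higher number from compound 2 to compound 3 (1.25 log units; beyond the scatter). Compound 1 and compound 2 both carry 4-aminophenyl there, so they showed nothing about this position. The value for compound 3 is a limit of the assay and not a number: the limit of > 100000 nM in this assay, at which 1 of the 3 values shown sits.

On these data alone, it remains open whether the step follows the loss of the amine or the entry of the two chlorines; a plain phenyl or a 4-chlorophenyl on the same carbon would separate the two. As far as these compounds go, how a 4-hydroxyphenyl would read there also remains open.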